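Chain-end methyl extension in chloromethyl ketone series

The source may report more compounds than this note shows. Statements on the series, on what has been measured and on what is new or still open speak of the compounds shown alone.

Compound 1 `CCCCSC[C@H](NC(C)=O)C(=O)CCl` gives 41400 nM in a functional assay on NALM-6 cells (Homo sapiens); a lower number here means a stronger inhibitor, a higher number a weaker inhibitor. Compound 2 `CCCCCSC[C@H](NC(C)=O)C(=O)CCl` gives 5800 nM, and compound 3 `CCCCCCCCCCCSC[C@H](NC(C)=O)C(=O)CCl` gives 1700 nM, the lowest number of the three. The change from compound 1 to compound 2 is methyl in place of hydrogen on a saturated chain carbon, four bonds along the chain from a sulfur, and it made a 7.1-fold lower number from compound 1 to compound 2 (0.85 log units; beyond the scatter). Compound 4 `CCCCCCCCCCCCSC[C@H](NC(C)=O)C(=O)CCl` differs from compound 3 by methyl in place of hydrogen on a saturated chain carbon, ten or more bonds along the chain from a sulfur, the same kind of change as that from compound 1 to compound 2, though at a different place along the chain. The core of compound 3 differs from that of compound 1 by heptyl in place of hydrogen on a saturated chain carbon, four bonds along the chain from a sulfur. Since a 3.4-fold lower number from compound 2 to compound 3 (0.53 log units; beyond the scatter) was smaller than the earlier step, the added carbon is expected to move the number only slightly, so compound 4 is expected to give 1200 nM, between 500 nM and 3000 nM, a step of a 1.4-fold lower number from compound 3 to compound 4 (0.15 log units; within the scatter).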

Compound 4, half-maximal inhibitory concentration: 2000 nM
The estimate for compound 4 lay 1.7-fold (0.22 log units) below the measured number; low and high end bracket the measured number.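

In this assay, methyl in place of hydrogen gave a 1.2-fold higher number from compound 3 to compound 4 (0.07 log units; within the scatter), so the gain seen at the shorter chain did not carry over to the core of compound 3: the same change on two cores in this assay, a 7.1-fold lower number (0.85 log units; beyond the scatter) from compound 1 to compound 2 and a 1.2-fold higher number (0.07 log units; within the scatter) from compound 3 to compound 4, 8.4-fold (0.92 log units) apart, beyond the scatter of two such steps

The heptyl change kept its direction but differed in size, giving a 2.9-fold lower number from compound 2 to compound 4 (0.46 log units; beyond the scatter), which is a smaller step than the one on the core of compound 1: the same change on two cores in this assay, a 24-fold lower number (1.39 log units; beyond the scatter) from compound 1 to compound 3 and a 2.9-fold lower number (0.46 log units; beyond the scatter) from compound 2 to compound 4, 8.4-fold (0.92 log units) apart, beyond the scatter of two such steps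

Among these four compounds, the size of a chain extension therefore depends on the core that carries it, but the data do not show why, and they give no rule for other cores.

The compounds shown leave open whether a longer chain would change the number in this assay. They also leave open what a branched chain, or a chain ending in an amine or a carboxylic acid, would do.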